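A few compounds are considered here, and "the series" means these few. Any claim that something is new, unique, unknown or untested is made for them only; others in the source may bear on it.

Compound 2 `O=C(Nc1cccc(F)c1)C1CCN(C/C=C/c2ccccc2)CC1` stands at the weak end of what has been measured so far. Among the measured compounds shown here, in a functional assay on A549 cells (Homo sapiens) for inhibition, read by MTT assay, with a stated time of 72 h (a higher number here means a weaker inhibitor, a lower number a stronger inhibitor), compound 2 gives 43300 nM, and the only other measured compound, compound 1 `CCc1ccc(NC(=O)C2CCN(C/C=C/c3ccccc3)CC2)cc1`, gives 19600 nM in this assay. For the measured compounds named here, the single known step, a 2.2-fold higher number from compound 1 to compound 2 (0.34 log units; beyond the scatter), arose when 3-fluorophenyl replaced 4-ethylphenyl on the amide-type nitrogen. Compound 3 `O=C(Nc1nccs1)C1CCN(C/C=C/c2ccccc2)CC1` alters that same position again: 1,3-thiazol-2-yl in place of 3-fluorophenyl on an amide-type nitrogen. Going by the values given here, that earlier step bears on the new one only in that it concerns the same place; the exchange of a six-membered carbon ring for a five-membered ring with two hetero atoms is of a different kind, so its size cannot be read from the one step available. With nothing more to guide it, the expected step is small, in either direction: a 1.1-fold lower number from compound 2 to compound 3 (0.03 log units; within the scatter). Compound 3 is therefore estimated at 40000 nM, with a likely range from 10000 nM to 150000 nM.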

Compound 3, half-maximal inhibitory concentration: 34900 nM
The estimate for compound 3 lay 1.1-fold (0.06 log units) above the measured number; the range from low to high includes it.
By their numbers in this assay, from the lowest: compounds 1, 3 and 2 (each within the scatter of the next, the first and the last beyond it).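

In this assay, the place on the amide-type nitrogen also accepts 1,3-thiazol-2-yl, a five-membered aromatic ring with 2 hetero atoms, and the result is a 1.2-fold lower number from compound 2 to compound 3 (0.09 log units; within the scatter) and a 1.8-fold higher number from compound 1 to compound 3 (0.25 log units; within the scatter). Compound 3 therefore cannot be told apart from either of the other two compounds, even though compound 1 and compound 2 differ from each other beyond the scatter, so this exchange of a carbon-only six-membered ring for the thiazolyl ring with its 2 hydrogen-bond acceptors leaves no measurable mark here. Nothing available explains why these numbers stand so close together.

The compounds shown leave open what a piperidinyl group, a carboxylic acid or a longer alkyl chain would do at this place. They also leave open what a methyl group in place of the amide hydrogen would do.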